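From an Ethyl Ester to a Benzyl Ester

A few compounds are considered here, and "the series" means these few. Any claim that something is new, unique, unknown or untested is made for them only; others in the source may bear on it.

For the measured compounds named here, in an assay on membranes from CHO cells for displacement of a labelled ligand from adenosine receptor A1 (Homo sapiens), read by scintillation counting, with a stated time of 60 min, tested at 1 uM (a lower number here means less inhibition, a higher number more inhibition at the concentration tested (going by the name of the read-out)), compound 2 `CCOC(=O)C1=C(C)N(C)C(=O)NC1c1cccs1` gives 1%, while the only other measured compound, compound 1 `CC1=C(C(=O)OCC(C)C)C(c2ccsc2)NC(=S)N1`, gives 8%, and these two numbers lie within the usual scatter of each other. Compound 3 `CC1=C(C(=O)OCc2ccccc2)C(c2cccs2)NC(=O)N1C` has not yet been measured. It differs from compound 2 in one place: phenyl in place of methyl on a saturated chain carbon bound to an oxygen next to a carbonyl group. Going by the values given here, no measured pair shows what this change does, so the step from compound 2 to compound 3 is expected to be small, whether upward, downward or none beyond the scatter. Compound 3 is estimated at 5%, with a range from -5% to 20%. This expectation means a step of a number 4 percentage points higher from compound 2 to compound 3 (within the scatter).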

Compound 3, a percentage reported as inhibition, at one concentration (the size of the read-out at that concentration, not a potency): 50%
The estimate for compound 3 lay 45 percentage points below the measured number, and the stated range ends below it.
By their numbers in this assay, from the lowest: compounds 2 and 1 (each within the scatter of the next); then compound 3.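

Replacing methyl with phenyl on this saturated chain carbon, turning the ethyl ester into a benzyl ester, gives a number 49 percentage points higher from compound 2 to compound 3 (beyond the scatter). The group at this place can therefore change the inhibition reading strongly, which compounds 1 and 2 could not show, as they differ in more than one place. No measurement shown here explains the size of this step.

Going by these compounds, it remains open whether the aromatic ring is what matters, or whether a cyclohexyl group or a longer chain such as propyl would do the same. This single step also cannot show whether the change would act alike on another core.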